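A few compounds are considered here, and "the series" means these few. Any claim that something is new, unique, unknown or untested is made for them only; others in the source may bear on it.

Compound 1, `CCCOc1ccc(C[C@@H](Cc2ccccc2)C(=O)O)cc1CNC(=O)c1ccc(-c2ccncc2)cc1`: 34.1 ug/mL
Compound 2, `CCCOc1ccc(C[C@@H](Cc2ccccc2)C(=O)O)cc1CNC(=O)c1ccc(-c2ccccc2C)cc1`: < 1 ug/mL
Compound 3, `CCCOc1ccc(C[C@@H](Cc2ccccc2)C(=O)O)cc1CNC(=O)c1ccc(-c2cccnc2)cc1`: 69.5 ug/mL

In a physicochemical assay for solubility, read by HPLC, in phosphate buffer, measured as thermodynamic solubility, with a stated time of 48 h, at pH 7.2 (a higher number here means a more soluble compound, a lower number a less soluble compound), compound 2 gives only a limit of the assay, < 1 ug/mL, which is the limit of < 1 ug/mL in this assay, at which 1 of the 3 values shown sits. Compound 4, `CCCOc1ccc(C[C@@H](Cc2ccccc2)C(=O)O)cc1CNC(=O)c1ccc(-c2ccccn2)cc1`, has not yet been measured; it differs from compound 2 by pyridin-2-yl in place of 2-methylphenyl on an aromatic carbon. The measured steps that bear on this are an at least 69-fold higher number from compound 2 to compound 3 (1.84 log units; beyond the scatter) and, in the other direction, an at least 34-fold lower number from compound 1 to compound 2 (1.53 log units; beyond the scatter), both large. Compound 1 and compound 3 show that the two pyridyl positions differ only modestly, a 2.0-fold higher number from compound 1 to compound 3 (0.31 log units; beyond the scatter). A large upward step an at least 30-fold higher number from compound 2 to compound 4 (1.47 log units; beyond the scatter) is therefore expected for compound 4. The solubility of compound 4 in this assay is estimated at 30 ug/mL, with a range from 8 ug/mL to 90 ug/mL.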

Compound 4, solubility: 17 ug/mL
Compound 4: middle estimate off by 1.8-fold (0.25 log units), on the high side; measured number inside the range.
By their numbers in this assay, from the lowest: compounds 4 and 1 (each within the scatter of the next); then compound 3. At a limit, below all of these: compound 2.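

In this assay pyridin-2-yl widens the spread among the pyridyl groups para to a large group: a 4.1-fold lower number from compound 3 to compound 4 (0.61 log units; beyond the scatter) is a modest step, whereas a 2.0-fold lower number from compound 1 to compound 4 (0.30 log units; within the scatter) stays within the scatter. Even so, an at least 17-fold higher number from compound 2 to compound 4 (1.23 log units; beyond the scatter) shows that pyridin-2-yl, like the other two pyridyl groups, stands well clear of 2-methylphenyl. That step rests on compound 2, whose value is a limit and not a number: the limit of < 1 ug/mL in this assay, at which 1 of the 4 values shown sits. Going by these compounds, whether an amine or a carboxylic acid on the pyridin-3-yl group, or a piperidine ring in its place, would raise the number further in this assay stays open.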